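A Phenyl for an Ethyl on the Ring Nitrogen

The source may hold more compounds than are shown below. What is called first, only, known or untested is meant among the compounds shown, and "the series" means these compounds.

Of the compounds shown here, three have so far been measured in a functional assay (aorta) for inhibition, with Homo sapiens as the target, using microsomes, in the presence of a further agent that is not named here; on this read-out lower numbers stand for stronger inhibition and higher numbers for weaker inhibition. Compound 1 `CCOC(=O)/C(C)=C\c1ccc(Cc2cccnc2)n1CC` gives 14000 nM in this assay. Compound 2 `CCOC(=O)/C(C)=C\c1cc(Cc2cccnc2)n(C(C)(C)C)c1` gives 3200 nM in this assay, and compound 3 `CCOC(=O)/C(C)=C\c1ccc(Cn2ccnc2)[nH]1` gives 8100 nM in this assay. Among these three, compound 1 stands at the highest number: the number for compound 3 lies within the usual scatter of it, while the number for compound 2 lies beyond the scatter, so only compound 2 can be called a stronger inhibitor than compound 1. Within the data shown here, no two of the measured compounds differ in one place alone, so no single structural step has yet been characterised by measurement.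

Compound 4 `CCOC(=O)/C(C)=C\c1ccc(Cc2cccnc2)n1-c1ccccc1` has not yet been measured. It differs from compound 1 in one place: phenyl in place of ethyl on an aromatic nitrogen. Among the measured compounds shown here, none of the measured compounds carries this exact change, so the expectation rests only on the fact that the values of compounds 1, 2 and 3 all sit in the same broad region of weak inhibition. Compound 4 is therefore expected to show a modest step toward stronger inhibition, a 2.0-fold lower number from compound 1 to compound 4 (0.30 log units; within the scatter), of a size that may not clear the scatter. The estimate for compound 4 is 7000 nM, with a range from 2000 nM to 25000 nM.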

Compound 4, half-maximal inhibitory concentration: 180000 nM
The estimate for compound 4 lay 26-fold (1.41 log units) below the measured number; measured number above the stated range.
By their numbers in this assay, from the lowest: compound 2; then compounds 3 and 1 (each within the scatter of the next); then compound 4.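

In this assay, the change from ethyl to phenyl on the aromatic nitrogen gives a 13-fold higher number from compound 1 to compound 4 (1.11 log units; beyond the scatter) and thus weakens inhibition. Among these compounds, this is the first single structural step that can be read, and it shows that the group on this nitrogen, in the core of compound 1, can shift the number by well beyond the scatter, whereas the earlier values alone showed only compounds that differ in more than one place. The step is also large, and it moves compound 4 clear of the other three compounds, so the swap of two carbon atoms for a six-membered aromatic ring of carbon only is not a neutral exchange here; the data shown offer no measurement that explains this loss of inhibition.

One step cannot separate the presence of the aromatic ring from the larger number of heavy atoms that enters with it. Going by these compounds, whether a longer chain such as n-butyl, a cyclohexyl ring or a benzyl group on this nitrogen would read like ethyl or like phenyl remains open, as does the outcome for a methyl group or a plain hydrogen there.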